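Swapping cyclopropyl for tert-butyl in compound 1

The compounds below may be only part of what the source reports. "The series", "measured", "known", "first", "only" and "open" are said of these compounds alone.

Values measured in a functional assay on cells (Burkitts lymphoma cell, Homo sapiens) for antiproliferative activity, read by MTT assay (on this read-out higher numbers stand for weaker inhibition and lower numbers for stronger inhibition), follow
Compound 1 (`c1ccc(/C(=N/Nc2nc3ccccc3o2)C2CC2)nc1`) 185 nM
Compound 2 (`C/C(=N\Nc1nc2ccccc2o1)c1cc(C)ncn1`) 42 nM

Compound 1 holds the higher of the two numbers, so it is the weaker inhibitor, and its gap to compound 2 lies beyond the scatter. Compound 3 (`CC(C)(C)/C(=N\Nc1nc2ccccc2o1)c1ccccn1`) has tert-butyl in place of cyclopropyl on a carbon with a double bond to nitrogen. Among the measured compounds shown here, no measured pair shows this change, so the expectation rests on the structural change alone. The step expected in this assay is small and within the scatter (a 1.1-fold higher number from compound 1 to compound 3 (0.03 log units; within the scatter)). For compound 3 the estimated value is 200 nM (expected range 60 nM to 700 nM).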

Compound 3, half-maximal inhibitory concentration: > 10000 nM
Compound 3 ended at the assay's limit; the forecaster's own chance of this, stated with the estimate: 3%; middle value at least 50-fold (1.69 log units) away from the limit.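

In this assay compound 3 gives > 10000 nM, which is a limit of the assay and not a number. On this carbon with a double bond to nitrogen, replacing the cyclopropyl ring with tert-butyl gives an at least 54-fold higher number from compound 1 to compound 3 (1.73 log units; beyond the scatter), so the position does not treat these two carbon groups alike. The size of this step is bounded from one side only: the limit of > 10000 nM in this assay, at which 1 of the 3 values shown sits.

As far as these compounds go, what an isopropyl group, a longer chain such as n-butyl, or an amine would give on this carbon remains open. So does whether the same swap has a comparable effect on another core.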